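This account rests on a few compounds, and the source may have more. Where it says the series, first, only, none or still open, it means among the compounds named here.

Measured compounds:
- compound 1 `O=C(c1ccc2c(c1)OCCO2)C1CCN(Cc2coc(-c3ccc(Cl)cc3)n2)CC1`: > 150 ug/mL
- compound 2 `COc1ccc(-c2nc(CN3CCC(C(=O)c4ccc5c(c4)OCCO5)CC3)co2)cc1`: > 150 ug/mL

In an ADME assay on HEK293 cells (Homo sapiens) for cytotoxicity, read by MTT assay, with a stated time of 36 h (a higher number here means a weaker inhibitor, a lower number a stronger inhibitor), compound 1 gives > 150 ug/mL, a limit of the assay rather than a number. In this assay compound 2 gives > 150 ug/mL, again a limit and not a number. Among the compounds with values here, compound 2 therefore stands at the limit, as does the one further value shown; the step that the two limits leave unreadable from compound 1 to compound 2 is consequently not readable in size or direction. The evidence on the measured values is the limit of > 150 ug/mL in this assay, at which 2 of the 2 values shown sit.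

Compound 3 `O=C(c1ccc2c(c1)OCCO2)C1CCN(Cc2coc(-c3ccoc3)n2)CC1` differs from compound 2 by furan-3-yl in place of 4-methoxyphenyl on an aromatic carbon. The only measured step is the unreadable one from compound 1 to compound 2, so no step of known size bears on this change, and no direction beyond the scatter can be expected in this assay from the numbers shown. Given that both measured compounds sit at the limit, compound 3 is expected to give 150 ug/mL, within 75 ug/mL to 300 ug/mL, meaning an expected step of a number no higher from compound 2 to compound 3 (the limit leaves the size open).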

Compound 3, half-maximal inhibitory concentration: > 150 ug/mL
Compound 3 gave a limit, no number; the forecaster's own chance of this, stated with the estimate: 75%; the middle value sits exactly at the limit.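

Compound 3 gives > 150 ug/mL in this assay, a limit and not a number. Within the data shown here, no step among compound 1, compound 2 and compound 3 can therefore be read. The compounds shown leave open whether exchanging the group on the shared core changes the read-out at all: the limit of > 150 ug/mL in this assay, at which 3 of the 3 values shown sit.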